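Ethyl to methyl on a shared core, all values at the limit

The source may report more compounds than this note shows. Statements on the series, on what has been measured and on what is new or still open speak of the compounds shown alone.

Compound 3 `CCc1ccc(NC(=S)N/N=C/c2cccs2)cc1` was tested in a functional assay on HT-29 cells (Homo sapiens) for inhibition, read by sulforhodamine B assay, with a stated time of 48 h; a lower number here means a stronger inhibitor of growth, a higher number a weaker inhibitor of growth. In this assay compound 3 gives > 100000 nM, a limit of the assay rather than a number. Compound 1 `S=C(N/N=C/c1cccs1)Nc1ccccc1` gives > 100000 nM, likewise a limit. Compound 2 `S=C(N/N=C/c1cccs1)Nc1cccc2ccccc12` gives > 100000 nM, again a limit. Compound 3 therefore stands at the limit of > 100000 nM in this assay, at which 3 of the 3 values shown sit. The change to compound 4 `Cc1ccc(NC(=S)N/N=C/c2cccs2)cc1` is hydrogen in place of methyl on a saturated chain carbon bound to an aromatic carbon. For the measured compounds named here, the only step in this region, a step that the two limits leave unreadable from compound 1 to compound 3, runs between two limits and its size cannot be read. Going by the values given here, no measured step therefore tells how the change from compound 3 to compound 4 should move this assay, and with every measured compound at the limit, a limit is expected once more. Compound 4 is expected to give 150000 nM, within 40000 nM to 600000 nM, an expected step that the limit leaves unreadable from compound 3 to compound 4.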

Compound 4, concentration for 50% growth inhibition: > 100000 nM
Compound 4 ended at the assay's limit (the forecaster's own chance of this, stated with the estimate: 85%); the middle value lies beyond the limit too.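

For the compounds shown here, compound 1, compound 3 and compound 4 all sit at a limit in this assay, so no step among them can be read: the limit of > 100000 nM in this assay, at which 4 of the 4 values shown sit. The compounds shown leave open whether any change to the shared core brings growth inhibition within measurable range.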